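Swapping 4-methoxy-3-methylphenyl for 3,4-dihydroxyphenyl on a shared core

This account rests on a few compounds, and the source may have more. Where it says the series, first, only, none or still open, it means among the compounds named here.

Among the compounds with values here, in a functional assay on NCI-H520 cells (Homo sapiens) for cytotoxicity (on this read-out higher numbers stand for weaker inhibition of growth and lower numbers for stronger inhibition of growth), compound 1 (`COc1ccc(C2=C(c3ccc(SC)cc3)CC3CCCN3C2=O)cc1C`) gives 100 nM, the lower of the two numbers measured so far. Within the data shown here, its only measured neighbour, compound 2 (`COc1ccc(C2=C(c3ccc(SC)cc3)CC3CCCN3C2=O)cc1OC`), gives 2000 nM. Compound 3 (`CSc1ccc(C2=C(c3ccc(O)c(O)c3)C(=O)N3CCCC3C2)cc1`) has not yet been measured. It keeps the core of compound 1 but carries 3,4-dihydroxyphenyl in place of 4-methoxy-3-methylphenyl on a double-bonded ring carbon.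

Among the measured compounds shown here, one measured step bears on this change. With methoxy in place of methyl on an aromatic carbon of the same group, the result was a 20-fold higher number from compound 1 to compound 2 (1.30 log units; beyond the scatter), a large change beyond the scatter. Compound 3 also loses that methyl and gains an oxygen-bearing group in its place. For the measured compounds named here, no measured step covers hydroxy in place of methoxy, so the evidence is thin and the range must stay wide. A large move towards a higher number is nevertheless expected in this assay, of about the size seen for compound 2. The expected step is a 20-fold higher number from compound 1 to compound 3 (1.30 log units; beyond the scatter). For compound 3 the estimate is 2000 nM, with an expected range from 400 nM to 10000 nM.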

Compound 3, concentration for 50% growth inhibition: 60000 nM
Estimate against measurement, compound 3: 30-fold (1.48 log units) below; measured number outside the range, above it.
By their numbers in this assay, from the lowest: compound 1; then compound 2; then compound 3.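

With 3,4-dihydroxyphenyl on the double-bonded ring carbon, this assay gives a 600-fold higher number from compound 1 to compound 3 (2.78 log units; beyond the scatter), so this position can lose far more growth inhibition than the swap of methyl for methoxy alone had shown. The numbers also continue in one direction across the three aryl groups shown: compound 1 gives 100 nM, compound 2 gives 2000 nM and compound 3 gives 60000 nM, so the 4-methoxy-3-methylphenyl group of compound 1 remains the best of these at this position, while 3,4-dihydroxyphenyl is the poorest. Nothing available here explains why the two hydroxy groups go with so high a number.

The compounds shown cannot separate the part played by each hydroxy group, since compound 3 changes both ring substituents of compound 1 at once, and a single-hydroxy group such as 3-hydroxy-4-methoxyphenyl would bear directly on that. They also leave open how an amine or a carboxylic acid on this aromatic ring would behave, and whether the same trend holds when the 4-(methylsulfanyl)phenyl group on the neighbouring ring atom is replaced.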